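The source may report more compounds than this note shows. Statements on the series, on what has been measured and on what is new or still open speak of the compounds shown alone.

Measured compounds in a functional assay on HEK293 cells (Homo sapiens) for cytotoxicity; a higher number here means that more compound is tolerated, a lower number that less compound is tolerated:
- compound 1, `COc1ccc([C@H]2CC(=O)N(c3ccc(N)cc3)C2)cc1OC1CCCC1`: in this assay compound 1 gives > 10000 nM, which is a limit of the assay rather than a number.
- compound 2, `COc1ccc([C@H]2CC(=O)N(c3cc(N)cc(F)c3)C2)cc1OC1CCCC1`: compound 2 gives > 10000 nM, again a limit.
- compound 3, `COc1ccc([C@H]2CC(=O)N(c3cccc(C)c3)C2)cc1OC1CCCC1`: compound 3 gives > 10000 nM, also a limit.

All three share one core and differ only in the aromatic group on the amide-type nitrogen in the ring. Because each value sits at the limit of > 10000 nM in this assay, at which 3 of the 3 values shown sit, none of the steps between them can be read: a step that the two limits leave unreadable from compound 1 to compound 2, a step that the two limits leave unreadable from compound 1 to compound 3 and a step that the two limits leave unreadable from compound 2 to compound 3 all remain of unknown size. Compound 3 therefore stands exactly where the other two stand, at a limit and not at a number.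

Compound 4, `COc1ccc([C@H]2CC(=O)N(c3cccc(NS(=O)(=O)c4cccc(C)c4)c3)C2)cc1OC1CCCC1`, differs from compound 3 in a single place: ((3-methylphenyl)sulfonyl)amino in place of methyl on an aromatic carbon. A small group is thus exchanged for a considerably more elaborate one. Among the compounds with values here, no measured step bears on such an exchange, since every step in this set is unreadable. Within the data shown here, the only guidance is that three different aromatic substituents all left tolerance at the limit. Compound 4 is therefore expected to stay near that limit, an expected step that the limit leaves unreadable from compound 3 to compound 4. The estimated value of compound 4 is 15000 nM, with an expected range from 4000 nM to 50000 nM.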

Compound 4, half-maximal cytotoxic concentration: > 10000 nM
Compound 4 gave a limit, no number; the forecaster's own chance of this, stated with the estimate: 70%; the middle value does not contradict the limit.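

In this assay compound 4 gives > 10000 nM, which is a limit and not a number. The step from compound 3 to compound 4 therefore cannot be read, because both compounds stand at the same limit: the limit of > 10000 nM in this assay, at which 4 of the 4 values shown sit. The compounds shown leave open at what concentration, if any, each becomes cytotoxic, and so how their aromatic groups compare.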